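Benzimidazole halogen swap on the somatostatin receptor 2 series

The source may report more compounds than this note shows. Statements on the series, on what has been measured and on what is new or still open speak of the compounds shown alone.

Measured compounds:
compound 1 `NC1CCN(c2c(-c3cc(F)cc(Cl)c3)cncc2-c2nc3cc(F)ccc3[nH]2)CC1` gives 0.081 nM in a functional assay on CHO-K1 cells for agonist activity at somatostatin receptor type 2 (Homo sapiens), read by cAMP accumulation, with a stated time of 30 min; a higher number here means that more compound is needed for the effect, a lower number that less compound is needed
compound 2 `Cc1cc(F)cc(-c2cncc(-c3nc4cc(F)ccc4[nH]3)c2N2CCC(N)CC2)c1` gives 0.019 nM in this assay
compound 3 `Cc1cc(C)cc(-c2cncc(-c3nc4cc(Cl)ccc4[nH]3)c2N2CCC(N)CC2)c1` gives 0.015 nM in this assay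

Compound 3 gives the lowest number of the three. Its nearest neighbour is compound 2, and the two lie within the scatter of each other; compound 1 is the furthest away, beyond the scatter. Within the data shown here, the one single-point step in hand is a 4.3-fold lower number from compound 1 to compound 2 (0.63 log units; beyond the scatter), a change on the phenyl ring, not on the benzimidazole.

Compound 4 `Cc1cc(C)cc(-c2cncc(-c3nc4cc(F)ccc4[nH]3)c2N2CCC(N)CC2)c1` differs from compound 3 by fluoro in place of chloro on an aromatic carbon. Among the measured compounds shown here, no measured pair isolates this change. Compounds 1 and 2 both carry the fluoro benzimidazole and compound 3 the chloro one, but compounds 2 and 3 also differ on the phenyl ring, so their values, within the scatter of each other, only suggest that the halogen on the benzimidazole does not move the number much in this context.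

On that basis no step beyond the scatter is expected in this assay for compound 4, and the estimated step is a 1.2-fold higher number from compound 3 to compound 4 (0.08 log units; within the scatter). Compound 4 is therefore expected to give about 0.018 nM, within a range from 0.007 nM to 0.045 nM.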

Compound 4, half-maximal effective concentration: 0.013 nM
Compound 4: middle estimate off by 1.4-fold (0.14 log units), on the high side; measured number inside the range.
By their numbers in this assay, from the lowest: compounds 4, 3 and 2 (each within the scatter of the next); then compound 1.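

In this assay, the change from 5-chloro-1H-benzimidazol-2-yl to 5-fluoro-1H-benzimidazol-2-yl now has a matched pair on the 3,5-dimethylphenyl background, and a 1.2-fold lower number from compound 3 to compound 4 (0.06 log units; within the scatter) shows that fluoro and chloro at this position cannot be told apart in this assay. Among these compounds, with the fluoro benzimidazole held fixed, the phenyl ring can also be read: methyl in place of fluoro gives a 1.5-fold lower number from compound 2 to compound 4 (0.16 log units; within the scatter) and so adds nothing that can be resolved, whereas the full change from 3-chloro-5-fluorophenyl to 3,5-dimethylphenyl gives a 6.2-fold lower number from compound 1 to compound 4 (0.79 log units; beyond the scatter) and is the only step of the two that is beyond the scatter. Among these four compounds the differences that can be resolved therefore lie on the phenyl ring and set compound 1 apart, while nothing in hand explains them.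

The compounds shown leave open whether this position tolerates anything other than a halogen, such as a methoxy group, a nitrile or a carboxylic acid. On these data alone, whether the halogen swap stays this small on the 3-chloro-5-fluorophenyl ring also remains open.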